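The source may report more compounds than this note shows. Statements on the series, on what has been measured and on what is new or still open speak of the compounds shown alone.

Compound 1 `CC(CCNC(=O)c1c(Cl)cncc1Cl)N1CCC(C(Oc2cccc(C(=O)O)n2)c2ccc(C(F)(F)F)cc2)CC1` was tested in an ADME assay on PBMC cells (Homo sapiens) for cytotoxicity (on this read-out higher numbers stand for lower toxicity in this test and lower numbers for higher toxicity in this test), where compound 1 gives 28700 nM. Of the three compounds measured, this is the smallest number, but compound 2 `CCO/N=C(/c1ccc(Br)cc1)C1CCN(C2(CCNC(=O)c3c(Cl)cncc3Cl)CC2)CC1`, which in this assay gives 33000 nM, lies within the usual scatter of compound 1, so the two cannot be told apart. Compound 3 `CCO/N=C(/c1ccc(Br)cc1)C1CCN(C(C)CNC(=O)c2c(C)cc[n+]([O-])c2C)CC1`, with 182000 nM in this assay, stands clearly beyond that scatter, at a higher number than compound 1.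

Compound 4 `CC(CCNC(=O)c1c(Cl)cncc1Cl)N1CCC(C(Oc2ccccc2Cl)c2ccc(C(F)(F)F)cc2)CC1` has not been measured. It differs from compound 1 in a single place: 2-chlorophenyl in place of 6-carboxypyridin-2-yl on an oxygen on a saturated carbon. Going by the values given here, no pair of measured compounds shows this same change, so there is no measured step to lean on, and the expectation rests only on the values of compounds 1 to 3 and on the change itself. A shift of modest size is expected, with compound 4 somewhat more likely to give a lower number than compound 1 than a higher one, and the estimated step of a 1.9-fold lower number from compound 1 to compound 4 (0.28 log units; within the scatter) is kept small. On that basis compound 4 is expected to give about 15000 nM in this assay, most likely between 5000 nM and 50000 nM.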

Compound 4, half-maximal cytotoxic concentration: 4400 nM
Estimate against measurement, compound 4: 3.4-fold (0.53 log units) above; the whole stated range lies above it.
By their numbers in this assay, from the lowest: compound 4; then compounds 1 and 2 (each within the scatter of the next); then compound 3.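

In this assay, putting 2-chlorophenyl in place of 6-carboxypyridin-2-yl on the oxygen gives a 6.5-fold lower number from compound 1 to compound 4 (0.81 log units; beyond the scatter), a step beyond the usual scatter towards higher toxicity in this test. This shows that the group on this oxygen matters in this test, which compounds 1 to 3 could not show, as they differ from one another in more than one place. The swap changes several things at once: a ring nitrogen and a carboxylic acid leave, a chlorine enters, and the count of hydrogen-bond donors and acceptors falls to zero, but nothing measured here says which of these matters or why the number moves.

From the compounds shown here alone, what remains open is which part of the swap carries the step, and a plain phenyl, a pyridin-2-yl without the carboxylic acid, or the methyl ester of that acid on the same oxygen would begin to separate these parts. Going by these compounds, whether the same swap would move the number by a similar amount on a different core also stays unknown, as this single pair speaks only for the core of compound 1.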